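This account rests on a few compounds, and the source may have more. Where it says the series, first, only, none or still open, it means among the compounds named here.

Working notes on the series. Compound 1 `O=C(OC1(C(=O)Nc2ccc([N+](=O)[O-])cc2)CCCCC1)c1ccc(Cl)cc1` in an ADME assay on WI-38 cells (Homo sapiens) for inhibition, read by MTT assay, with a stated time of 72 h (on this read-out higher numbers stand for weaker inhibition and lower numbers for stronger inhibition), gives 355 nM. Compound 2 `COc1ccc(C(=O)OC2(C(=O)Nc3ccc([N+](=O)[O-])cc3)CCCCC2)cc1` in this assay gives 40 nM. Compound 3 `O=C(OC1(C(=O)Nc2ccc([N+](=O)[O-])cc2)CCCCC1)c1ccc([N+](=O)[O-])cc1` in this assay gives 761 nM, the highest number of the three, reached by a 2.1-fold higher number from compound 1 to compound 3 (0.33 log units; beyond the scatter) and by a 19-fold higher number from compound 2 to compound 3 (1.28 log units; beyond the scatter). Compound 4 `O=COC1(C(=O)Nc2ccc([N+](=O)[O-])cc2)CCCCC1` carries the next change, (hydrogen in place of 4-nitrophenyl on a carbonyl carbon), on a carbonyl carbon whose other neighbour is oxygen next to a carbonyl group. Among the compounds with values here, no measured step removes an aryl group outright; an 8.9-fold lower number from compound 1 to compound 2 (0.95 log units; beyond the scatter), a 2.1-fold higher number from compound 1 to compound 3 (0.33 log units; beyond the scatter) and a 19-fold higher number from compound 2 to compound 3 (1.28 log units; beyond the scatter) only show that substitution on the ring compound 4 loses moves the number well beyond the scatter. A step of a 2.0-fold higher number from compound 3 to compound 4 (0.29 log units; within the scatter) toward a higher number is therefore expected, with wide uncertainty. For compound 4 the estimate in this assay is 1500 nM, between 300 nM and 8000 nM.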

Compound 4, half-maximal inhibitory concentration: 46.3 nM
Compound 4: middle estimate off by 32-fold (1.51 log units), on the high side, and the stated range ends above it.
By their numbers in this assay, from the lowest: compounds 2 and 4 (each within the scatter of the next); then compound 1; then compound 3.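

In this assay the steps of a 16-fold lower number from compound 3 to compound 4 (1.22 log units; beyond the scatter) and a 7.7-fold lower number from compound 1 to compound 4 (0.88 log units; beyond the scatter) show that an aryl group on this carbonyl carbon is not needed for a low number, since hydrogen there goes with the lower number in both pairs. The step of a 1.2-fold higher number from compound 2 to compound 4 (0.06 log units; within the scatter) lies within the scatter, so of the three aryl groups only 4-methoxyphenyl matches hydrogen at this position. Nothing at hand accounts for these steps. Open, going by these compounds, is what a small alkyl group such as methyl, an amine or a longer chain would give on this carbonyl carbon.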